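Removing a nitro group, then trimming a side chain

This account rests on a few compounds, and the source may have more. Where it says the series, first, only, none or still open, it means among the compounds named here.

Compound 1, with the structure `CCC(C)C(C(=O)Nc1ccc(C(C)=O)cc1)N(C(=O)c1ccccc1)S(=O)(=O)c1ccc([N+](=O)[O-])cc1`, is the reference point. In a functional assay for inhibition, read by spectrophotometry, with a stated time of 20 min, tested at 1 mg/mL (on this read-out higher numbers stand for a stronger effect at the one concentration tested and lower numbers for a weaker effect), compound 1 gives 28.6%. Compound 2, with the structure `CC(=O)c1ccc(NC(=O)C(C(C)C)N(C(=O)c2ccccc2)S(=O)(=O)c2ccc([N+](=O)[O-])cc2)cc1`, differs from compound 1 by hydrogen in place of methyl on a saturated chain carbon, three bonds along the chain from an amide-type nitrogen and a carbonyl carbon. In this assay compound 2 gives 29.8%, so the step of a number 1.2 percentage points higher from compound 1 to compound 2 (within the scatter) is one that cannot be told apart from noise.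

Compound 3, with the structure `CCC(C)C(C(=O)Nc1ccc(C(C)=O)cc1)N(C(=O)c1ccccc1)S(=O)(=O)c1ccccc1`, differs from compound 1 by hydrogen in place of nitro on an aromatic carbon. In this assay compound 3 gives 9.71%. Here the step of a number 18.9 percentage points lower from compound 1 to compound 3 (beyond the scatter) is the only clear movement among the three measured compounds, and compound 3 stands lowest of the three.

Compound 4, with the structure `CC(=O)c1ccc(NC(=O)C(C(C)C)N(C(=O)c2ccccc2)S(=O)(=O)c2ccccc2)cc1`, has not yet been measured. It differs from compound 3 by hydrogen in place of methyl on a saturated chain carbon, three bonds along the chain from an amide-type nitrogen and a carbonyl carbon, and this is the same change already seen between compound 1 and compound 2, made on the core that lacks the nitro group. That change occurs twice among these compounds. Because a number 1.2 percentage points higher from compound 1 to compound 2 (within the scatter) stayed within the scatter, the expectation is that the step of a number 1.3 percentage points higher from compound 3 to compound 4 (within the scatter) will also be small. Compound 4 is therefore estimated to give 11% in this assay, with a likely range from 0% to 23%. This estimate rests on one earlier pair only, so the true value could sit anywhere in that range.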

Compound 4, a percentage reported as inhibition, at one concentration (the size of the read-out at that concentration, not a potency): 32.1%
Beside the measured number, compound 4's estimate is 21.1 percentage points below it; measured number above the stated range.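

In this assay, the change from sec-butyl to isopropyl gave a number 22.4 percentage points higher from compound 3 to compound 4 (beyond the scatter), so on the core without the nitro group it was far from the silent step seen on the core of compound 1: the same change on two cores in this assay, a number 1.2 percentage points higher (within the scatter) from compound 1 to compound 2 and a number 22.4 percentage points higher (beyond the scatter) from compound 3 to compound 4, 21.2 percentage points apart, beyond the scatter of two such steps The nitro change behaved in the same core-dependent way, since hydrogen in place of nitro on an aromatic carbon now gave a number 2.3 percentage points higher from compound 2 to compound 4 (within the scatter), where the sec-butyl core had shown a clear drop: the same change on two cores in this assay, a number 18.9 percentage points lower (beyond the scatter) from compound 1 to compound 3 and a number 2.3 percentage points higher (within the scatter) from compound 2 to compound 4, 21.2 percentage points apart, beyond the scatter of two such steps Across these four compounds, then, neither change can be carried from one core to the other as a fixed increment, and only compound 3, which combines sec-butyl with the absence of nitro, stands apart, but a single square of compounds read at one concentration shows neither why the two changes depend on each other nor whether the same dependence would hold on any other core.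

The compounds shown leave open whether a longer chain or a cyclohexyl group in place of sec-butyl or isopropyl would read high or low on the core without the nitro group. They also leave open how an amine, a nitrile or a carboxylic acid in place of nitro would behave on either side chain, and whether any of these compounds would show a stronger or weaker effect at a concentration other than the one tested.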